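The compounds below may be only part of what the source reports. "The series", "measured", "known", "first", "only" and "open" are said of these compounds alone.

Compound 1 `Cc1ccc(/C=C/C(=O)Nc2nnc(-c3ccc(C)cc3)s2)cc1` — 1.08 ug/mL
Compound 2 `Cc1ccc(/C=C/C(=O)Nc2nnc(-c3ccc(Br)cc3)s2)cc1` — 1.51 ug/mL
Compound 3 `Cc1ccc(/C=C/C(=O)Nc2nnc(-c3ccc(Cl)cc3)s2)cc1` — 1.25 ug/mL

In a functional assay on A549 cells (Homo sapiens) for antiproliferative activity, read by MTT assay, with a stated time of 48 h (a higher number here means a weaker inhibitor, a lower number a stronger inhibitor), compound 3 holds the second highest of the three numbers. Its nearest neighbour is compound 1, reached by a 1.2-fold higher number from compound 1 to compound 3 (0.06 log units; within the scatter); the step of a 1.2-fold lower number from compound 2 to compound 3 (0.08 log units; within the scatter) is also within the scatter, so the three compounds cannot be ordered against one another on these numbers.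

Compound 4 `Cc1ccc(/C=C/C(=O)Nc2nnc(-c3ccccc3)s2)cc1` is the next member of the series. It differs from compound 3 by hydrogen in place of chloro on an aromatic carbon. The three measured steps bear on this change only loosely: each of a 1.4-fold higher number from compound 1 to compound 2 (0.15 log units; within the scatter), a 1.2-fold higher number from compound 1 to compound 3 (0.06 log units; within the scatter) and a 1.2-fold lower number from compound 2 to compound 3 (0.08 log units; within the scatter) exchanges one group on that ring for another, and all three stay within the scatter. None of them removes the group altogether, so the data do not show what a bare ring does here. Since every exchange so far left this assay essentially unchanged, the expected outcome is a step of a 1.3-fold higher number from compound 3 to compound 4 (0.11 log units; within the scatter) that is small and most likely within the scatter, with a slight lean towards a higher number. Compound 4 is therefore estimated at 1.6 ug/mL, with a plausible range from 0.9 ug/mL to 3 ug/mL.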

Compound 4, half-maximal inhibitory concentration: 1.58 ug/mL
Estimate against measurement, compound 4: 1.0-fold (0.01 log units) above, within the range that was stated.
By their numbers in this assay, from the lowest: compounds 1, 3, 2 and 4 (each within the scatter of the next).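

In this assay, the bare phenyl of compound 4 can be set against each substituted ring: the step of a 1.3-fold higher number from compound 3 to compound 4 (0.10 log units; within the scatter) for loss of chloro, the step of a 1.0-fold higher number from compound 2 to compound 4 (0.02 log units; within the scatter) for loss of bromo and the step of a 1.5-fold higher number from compound 1 to compound 4 (0.17 log units; within the scatter) for loss of methyl all lie within the scatter. The earlier compounds only exchanged one group for another, whereas these steps show that taking the group away altogether also leaves the number within the scatter, so none of these three groups is shown to be needed on this aromatic carbon for the activity seen here. Nothing in the available data explains why this position tolerates the change.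

The compounds shown leave open whether an amine, a carboxylic acid or a methoxy group on this carbon would also stay within the scatter in this assay given that the four compounds carry only hydrogen, methyl, chloro or bromo there. They also leave open whether a change elsewhere in the shared core, such as replacing the amide hydrogen with a methyl group or reducing the carbon-carbon double bond, would move the number any further.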